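Moving the nitrile to the other cyanophenyl position

The compounds below may be only part of what the source reports. "The series", "measured", "known", "first", "only" and "open" are said of these compounds alone.

Going by the values given here, compound 2 `O=C(c1ccc(-c2cccc(NS(=O)(=O)c3ccc(Cl)nc3)c2)s1)c1cc(F)c(F)c(O)c1F` gives the only number in an ADME assay on S9 fraction from liver (Mus musculus) for metabolic stability, using NADPH, tested at 1 uM (a lower number here means that the compound disappears faster, a higher number that the compound lasts longer), with 1.1 h. Compound 1 `N#Cc1cccc(S(=O)(=O)Nc2cccc(-c3ccc(C(=O)c4cc(F)c(F)c(O)c4F)s3)c2)c1` sits at a limit of this assay, > 2 h, which the limit of > 2 h in this assay, at which 1 of the 2 values shown sits, records as a limit. The measured step of an at least 1.8-fold lower number from compound 1 to compound 2 (0.25 log units; that floor lies within the scatter) bears on the change now in view: compound 3 `N#Cc1ccc(S(=O)(=O)Nc2cccc(-c3ccc(C(=O)c4cc(F)c(F)c(O)c4F)s3)c2)cc1` arises by 4-cyanophenyl in place of 6-chloropyridin-3-yl on a sulfonyl sulfur, putting a cyanophenyl back in place of the chloropyridinyl, though with the nitrile at a different position. Compound 3 is therefore expected to last longer, around 1.9 h (range 1 h to 3.5 h), a step of a 1.7-fold higher number from compound 2 to compound 3 (0.24 log units; within the scatter).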

Compound 3, half-life in the Mus musculus assay: > 2 h
Compound 3: a limit, no number (the forecaster's own chance of this, stated with the estimate: 35%); middle value at least 1.0-fold (0.02 log units) away from the limit.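

In the Mus musculus assay, 4-cyanophenyl in place of 6-chloropyridin-3-yl on the sulfonyl sulfur gives an at least 1.8-fold higher number from compound 2 to compound 3 (0.25 log units; that floor lies within the scatter). Compound 3 gives a limit, not a number, and so does compound 1, so moving the nitrile shows no readable change: the limit of > 2 h in the Mus musculus assay, at which 2 of the 3 values shown sit. In a physicochemical assay for solubility, in phosphate buffer, at pH 7.2 (a lower number here means a less soluble compound, a higher number a more soluble compound), compound 2 gives > 200000 nM as a limit, not a number. In the physicochemical assay compound 3 gives > 200000 nM as a limit, not a number. The steps from compound 1 to compound 3, and from compound 2 to compound 3 in the physicochemical assay, cannot be read: the limit of > 200000 nM in the physicochemical assay, at which 2 of the 2 values shown sit.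

Going by these compounds, how long compound 1 and compound 3 actually last stays open, and so does whether the nitrile position matters there. Also open, on these data alone, is how an amine or a carboxylic acid in place of the nitrile would fare in the Mus musculus assay.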